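The source may hold more compounds than are shown below. What is called first, only, known or untested is meant among the compounds shown, and "the series" means these compounds.

Measured so far:
compound 1 `Cc1cccc(Nc2nc(-c3ccnc(C)c3)cs2)c1` — in a functional assay on RCC4 cells (Homo sapiens) for inhibition, read by XTT assay, with a stated time of 4 days (a lower number here means a stronger inhibitor, a higher number a weaker inhibitor), compound 1 gives 28800 nM
compound 2 `CCc1cc(-c2csc(Nc3cccc(C)c3)n2)ccn1` — in this assay compound 2 gives 6460 nM

Within the data shown here, compound 2 holds the lower of the two numbers; the only step on record, a 4.5-fold lower number from compound 1 to compound 2 (0.65 log units; beyond the scatter), separates them. Compound 3 `Cc1cccc(Nc2nc(-c3ccnc(Br)c3)cs2)c1` differs from compound 2 by bromo in place of ethyl on an aromatic carbon. Among the measured compounds shown here, no measured step exchanges one group for another at this aromatic carbon, so the record gives no direct guide; the step to compound 3 is expected to stay close to compound 2, with a 1.4-fold higher number from compound 2 to compound 3 (0.14 log units; within the scatter) in either direction. Compound 3 is thus estimated at 9000 nM, within 2500 nM to 30000 nM.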

Compound 3, half-maximal inhibitory concentration: 2040 nM
Compound 3: the middle estimate sits 4.4-fold (0.64 log units) above what was measured, and the stated range ends above it.
By their numbers in this assay, from the lowest: compound 3; then compound 2; then compound 1.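

At this aromatic carbon, the earlier pair showed only a change between alkyl groups. Bromo in place of ethyl gives a 3.2-fold lower number from compound 2 to compound 3 (0.50 log units; beyond the scatter) in this assay and bromo in place of methyl gives a 14-fold lower number from compound 1 to compound 3 (1.15 log units; beyond the scatter) as the larger of the two steps, so the position also accepts a group that is not an alkyl chain, and the lowest number of the three belongs to it. Nothing on record accounts for this order of the three groups.

Still open, going by these compounds, is whether chloro or iodo at this carbon would follow bromo. Also open, on these data alone, is how an amine, a methoxy group or a chain longer than ethyl would compare.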